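The source may report more compounds than this note shows. Statements on the series, on what has been measured and on what is new or still open speak of the compounds shown alone.

Of the compounds shown here, three that share one core have so far been tested in a functional assay on MCF7 cells (Homo sapiens) for inhibition, read by MTT assay, with a stated time of 72 h; a higher number here means a weaker inhibitor, a lower number a stronger inhibitor. Compound 1 `O=C1O/C(=C\Cn2c(=O)[nH]c(=O)[nH]c2=O)C(OCc2ccccc2)=C1OCc1ccccc1` gives 17800 nM in this assay, the highest of the two plain numbers. Compound 3 `Nc1ccn(C[C@H](O)[C@H]2OC(=O)C(OCc3ccccc3)=C2OCc2ccccc2)c(=O)n1` gives 7340 nM in this assay, a lower number than compound 1 by a gap that lies beyond the usual scatter of such measurements. Compound 2 `NC1(CCn2ncc(=O)[nH]c2=O)OC(=O)C(OCc2ccccc2)=C1OCc1ccccc1` reaches only a limit of the assay in this assay, > 100000 nM, so no number is known for it; this is the limit of > 100000 nM in this assay, at which 1 of the 3 values shown sits.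

Compound 4 `Nc1ncn(C/C=C2\OC(=O)C(OCc3ccccc3)=C2OCc2ccccc2)c(=O)n1` is not yet measured. It differs from compound 1 in one place: a group of 8 heavy atoms (3 carbon, 4 nitrogen, 1 oxygen; one six-membered aromatic ring with 3 hetero atoms) in place of a group of 9 heavy atoms (3 carbon, 3 nitrogen, 3 oxygen; one six-membered aromatic ring with 3 hetero atoms), on a saturated chain carbon bound to a double-bonded chain carbon. For the measured compounds named here, no measured pair of compounds shows this exact change, so the size of the step has to be judged from what the three measured compounds show. The compounds with a six-membered aromatic ring carrying an amino group, compound 3 among the measured ones, sit at or below the number of compound 1, while compound 2 lies at a limit. A small step down from compound 1, of the order of the scatter or slightly beyond it, is therefore expected, a 1.6-fold lower number from compound 1 to compound 4 (0.21 log units; within the scatter). For compound 4 the estimated value in this assay is 11000 nM, with a likely range from 3500 nM to 35000 nM.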

Compound 4, half-maximal inhibitory concentration: 3490 nM
Compound 4: middle estimate off by 3.2-fold (0.50 log units), on the high side, and the stated range ends above it.
By their numbers in this assay, from the lowest: compound 4; then compound 3; then compound 1. At a limit, above all of these: compound 2.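

For the compounds shown here, the step of a 5.1-fold lower number from compound 1 to compound 4 (0.71 log units; beyond the scatter) is the first measured change at this place, on a saturated chain carbon bound to a double-bonded chain carbon, and it shows that this assay responds to what is attached there while the shared core stays the same. Both groups are a six-membered aromatic ring with 3 hetero atoms, so the ring type alone does not set the value, and the details of the ring count for a step of this size. The entering group differs from the leaving one in several ways at once: it has 1 double bond outside aromatic rings instead of 3, 1 hydrogen-bond donor instead of 2, and 5 hydrogen-bond acceptors instead of 4.

With only this one swap, the compounds shown cannot say which of these differences matters, or whether a dimethylamino group on the ring or a longer chain between the ring and the core would keep the lower number. Compound 2 remains a limit of the assay and offers no number for comparison: the limit of > 100000 nM in this assay, at which 1 of the 4 values shown sits.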